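The compounds below may be only part of what the source reports. "The series", "measured", "known", "first", "only" and "open" are said of these compounds alone.

The measured compounds are compound 1 `C=C1CC[C@@H]2[C@](C)(CO)[C@H](O)CC[C@@]2(C)[C@]1(O)CCC1=CCOC1=O`, compound 2 `C=C1CC[C@H]2[C@@](C)(CCC(=O)[C@@]2(C)CO)[C@@H]1CCC1=CCOC1=O` and compound 3 `C=C1CC[C@H]2[C@@](C)(CCC(=O)[C@@]2(C)CO)[C@@H]1/C=C/C1=CCOC1=O`. In a functional assay on RAW264.7 cells (Mus musculus) for inhibition, read by Griess assay, with a stated time of 24 h (a higher number here means a weaker inhibitor, a lower number a stronger inhibitor), compound 2 gives 10100 nM and compound 3 gives 75300 nM. For compound 1 the outcome in this assay is only a limit, > 100000 nM, as the limit of > 100000 nM in this assay, at which 1 of the 3 values shown sits, records. The difference between the core of compound 1 and the core of compound 2 is not broken down here.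

Compound 3 arises from compound 2 by a single change: a group of 8 heavy atoms (6 carbon, 2 oxygen; one five-membered non-aromatic ring with 1 hetero atom) in place of a group of 8 heavy atoms (6 carbon, 2 oxygen; one five-membered non-aromatic ring with 1 hetero atom), on a saturated ring carbon. That change gives a 7.5-fold higher number from compound 2 to compound 3 (0.87 log units; beyond the scatter).

The unmeasured compound 4 `C=C1CC[C@@H]2[C@](C)(CO)[C@H](O)CC[C@@]2(C)[C@]1(O)/C=C/C1=CCOC1=O` arises from compound 1 by the same change, at the same place: a group of 8 heavy atoms (6 carbon, 2 oxygen; one five-membered non-aromatic ring with 1 hetero atom) in place of a group of 8 heavy atoms (6 carbon, 2 oxygen; one five-membered non-aromatic ring with 1 hetero atom), on a saturated ring carbon. Among the compounds with values here, since compound 1 is known in this assay only as a limit, and the one measured instance of this change gave a 7.5-fold higher number from compound 2 to compound 3 (0.87 log units; beyond the scatter), there is no ground to expect compound 4 to read lower than compound 1. In this assay compound 4 is therefore estimated at 400000 nM, most likely between 100000 nM and 2000000 nM, and very probably reported again as a limit rather than a number; the expected step is a step that the limit leaves unreadable from compound 1 to compound 4.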

Compound 4, half-maximal inhibitory concentration: 97200 nM
The estimate for compound 4 lay 4.1-fold (0.61 log units) above the measured number; measured number below the stated range.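

In this assay the group with 3 double bonds outside aromatic rings, entering in place of the group with 2, gives an at least 1.0-fold lower number from compound 1 to compound 4 (0.01 log units; that floor lies within the scatter). On this evidence the change does not behave alike on the two cores: the same change on two cores in this assay, a 7.5-fold higher number (0.87 log units; beyond the scatter) from compound 2 to compound 3 and an at least 1.0-fold lower number (0.01 log units; that floor lies within the scatter) from compound 1 to compound 4, at least 7.6-fold (0.88 log units) apart, beyond the scatter of two such steps.

Compound 1 is known only as a limit, so its step is a floor and not a measured size: the limit of > 100000 nM in this assay, at which 1 of the 4 values shown sits.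

With a single pair on each core, this shows that the result of the change on the core of compound 2 did not carry over to the core of compound 1, but it does not show which difference between the cores is responsible or how the change would read on any further core.

The compounds shown leave open how a longer chain would read at the same place on either core. They also leave open whether an amine or a carboxylic acid on that chain, in place of the five-membered ring, would read differently on the two cores.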